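Replacing propoxy with methylsulfanyl on the shared core

This account rests on a few compounds, and the source may have more. Where it says the series, first, only, none or still open, it means among the compounds named here.

In a functional assay on MCF7 cells (Homo sapiens) for cytotoxicity (on this read-out higher numbers stand for an effect only at larger amounts of compound and lower numbers for an effect already at smaller amounts), compound 2 (`CCCOc1ccc(/C=C\c2cc(OC)c(OC)c(OC)c2)cc1`) gives 6.6 uM and stands within the scatter of compound 1 (`CCOc1ccc(/C=C\c2cc(OC)c(OC)c(OC)c2)cc1`) at 9.6 uM in the same read-out. Compound 3 (`COc1cc(/C=C\c2ccc(SC)cc2)cc(OC)c1OC`) has methylsulfanyl in place of propoxy on an aromatic carbon. Among the compounds with values here, the only measured step (a 1.5-fold lower number from compound 1 to compound 2 (0.16 log units; within the scatter)) concerns the chain and stays within the scatter, and no measured step replaces the propoxy group itself. In this assay a modest move to a lower number is tentatively expected for compound 3 (a 2.2-fold lower number from compound 2 to compound 3 (0.34 log units; beyond the scatter)). The estimate for compound 3 is 3 uM with an expected range (0.3 uM to 15 uM).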

Compound 3, concentration for half-maximal effect: 5.4 uM
Estimate against measurement, compound 3: 1.8-fold (0.26 log units) below; the measured number falls inside the stated range.
By their numbers in this assay, from the lowest: compounds 3, 2 and 1 (each within the scatter of the next).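

At this aromatic carbon, para to a large group, methylsulfanyl replaces propoxy (a 1.2-fold lower number from compound 2 to compound 3 (0.09 log units; within the scatter)) and ethoxy (a 1.8-fold lower number from compound 1 to compound 3 (0.25 log units; within the scatter)) in this assay. Thus, replacing the whole group, rather than only lengthening its chain, leaves the number within the scatter in both comparisons, although methylsulfanyl has fewer heavy atoms than propoxy and carries sulfur instead of oxygen. Nothing available explains this result. As far as these compounds go, whether an amine, a carboxylic acid or a longer sulfur-linked chain at this carbon would also stay within the scatter remains open.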